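A few compounds are considered here, and "the series" means these few. Any claim that something is new, unique, unknown or untested is made for them only; others in the source may bear on it.

In a functional assay on HCT-116 cells (Homo sapiens) for antiproliferative activity, read by WST assay, with a stated time of 72 h (a higher number here means a weaker inhibitor of growth, a lower number a stronger inhibitor of growth), compound 1 (`O=C(NO)c1cnc(N2C[C@@H]3[C@H](C2)[C@H]3NC(=O)c2cccs2)nc1`) gives 3600 nM and compound 2 (`O=C(NO)c1cnc(N2C[C@@H]3[C@H](C2)[C@H]3NC(=O)c2ccccc2)nc1`) gives 5100 nM on the same read-out, so compound 2 stands level with compound 1 within the scatter. Among the measured compounds shown here, the only measured step (a 1.4-fold higher number from compound 1 to compound 2 (0.15 log units; within the scatter)) is phenyl in place of thiophen-2-yl on a carbonyl carbon, and the carbonyl stays in place across it. Compound 3 (`O=C(NO)c1cnc(N2C[C@@H]3[C@H](C2)[C@H]3NCC2CCCCC2)nc1`) keeps the shared core but has cyclohexylmethyl in place of benzoyl on an amine nitrogen and so loses that carbonyl along with the benzoyl. For the measured compounds named here, no measured step in this small set covers such a change, and the one available step gives only a weak guide to its size. In this assay a step beyond the scatter towards a lower number is expected, though this is a judgement that carries wide uncertainty. The estimated step is a 7.3-fold lower number from compound 2 to compound 3 (0.86 log units; beyond the scatter) at the middle of the range. Compound 3 is expected at 700 nM with an estimated range from 150 nM to 3500 nM on this read-out.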

Compound 3, concentration for 50% growth inhibition: 160 nM
Compound 3: the middle estimate sits 4.4-fold (0.64 log units) above what was measured; low and high end bracket the measured number.
By their numbers in this assay, from the lowest: compound 3; then compounds 1 and 2 (each within the scatter of the next).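

In this assay, replacing the carbonyl-bearing group on the amine nitrogen produces a large change: cyclohexylmethyl in place of benzoyl gives a 32-fold lower number from compound 2 to compound 3 (1.50 log units; beyond the scatter), and cyclohexylmethyl in place of (thiophen-2-yl)carbonyl gives a 23-fold lower number from compound 1 to compound 3 (1.35 log units; beyond the scatter). The earlier step, with the carbonyl retained, showed only a 1.4-fold higher number from compound 1 to compound 2 (0.15 log units; within the scatter), which lies within the scatter, so this position had not previously shown a large response to change. The two new steps now show that it can respond strongly and that the lower number holds against both carbonyl-bearing compounds, while the data shown give no measured basis for a cause.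

Each new step removes the carbonyl and also replaces an aromatic ring with a non-aromatic six-membered ring of carbon only, so the compounds shown do not separate these two parts of the change. Benzyl on the same amine nitrogen would keep the aromatic ring without the carbonyl, cyclohexylcarbonyl would keep the carbonyl with the non-aromatic ring, and the effect of a longer chain between the nitrogen and the cyclohexyl ring also remains open.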